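A few compounds are considered here, and "the series" means these few. Any claim that something is new, unique, unknown or untested is made for them only; others in the source may bear on it.

Compound 3, `COC(=O)/C=C/[C@H]1OCCC[C@@H]1O[Si](C)(C)C(C)(C)C`, stands at 22000 nM in a functional assay on HL-60 cells (Homo sapiens) (on this read-out lower numbers stand for stronger inhibition of growth and higher numbers for weaker inhibition of growth), level with compound 2 at the digits shown, the two together being the lowest of the three numbers measured so far; compound 2, `COC(=O)/C=C/C[C@H]1OCCC[C@@H]1O[Si](C)(C)C(C)(C)C`, gives 22000 nM in this assay. Compound 1, `CC(C)(C)[Si](C)(C)O[C@H]1CCCO[C@@H]1CCO`, gives 46000 nM in this assay and is the furthest from compound 3, as a 2.1-fold lower number from compound 1 to compound 3 (0.32 log units; beyond the scatter) records. The step from compound 3 to compound 4, `CC(C)(C)[Si](C)(C)O[C@H]1CCCO[C@@H]1/C=C\CO`, is 3-hydroxyprop-1-en-1-yl in place of 2-(methoxycarbonyl)ethenyl on a saturated ring carbon. Within the data shown here, two measured steps bear on it. a 2.1-fold lower number from compound 1 to compound 3 (0.32 log units; beyond the scatter) shows that putting the ester-bearing chain in place of a hydroxyl-bearing chain on that ring carbon lowered the number modestly, and a 2.1-fold lower number from compound 1 to compound 2 (0.32 log units; beyond the scatter) shows the same shift for the related change on the chain carbon; no change at the digits printed from compound 2 to compound 3 (within the scatter) shows that the length of the ester-bearing chain did not matter. Compound 4 reverses the direction of those steps, going back to a hydroxyl-bearing chain, so a modest rise in the number, back toward compound 1, is expected, with an expected step of a 1.8-fold higher number from compound 3 to compound 4 (0.26 log units; within the scatter). Compound 4 is therefore estimated at 40000 nM in this assay, within a range from 15000 nM to 110000 nM.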

Compound 4, concentration for 50% growth inhibition: 26000 nM
Compound 4: middle estimate off by 1.5-fold (0.19 log units), on the high side; the range from low to high includes it.
By their numbers in this assay, from the lowest: compounds 2, 3, 4 and 1 (each within the scatter of the next, the first and the last beyond it).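

In this assay, the saturated ring carbon next to the ring oxygen accepts 3-hydroxyprop-1-en-1-yl in place of 2-(methoxycarbonyl)ethenyl with no change beyond the scatter (a 1.2-fold higher number from compound 3 to compound 4 (0.07 log units; within the scatter)), and the same holds against the longer ester-bearing chain (a 1.2-fold higher number from compound 2 to compound 4 (0.07 log units; within the scatter)). Compound 4 also stays within the scatter of the saturated hydroxyl-bearing chain (a 1.8-fold lower number from compound 1 to compound 4 (0.25 log units; within the scatter)), so it sits within reach of both ends of the one gap that the earlier compounds had shown beyond the scatter, and that gap can no longer be read as a simple contrast between an ester and a hydroxyl-bearing chain. No measurement on hand gives a reason for this behaviour.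

The compounds shown leave open whether an amine, a carboxylic acid or a much longer chain on this ring carbon would move the number beyond the scatter. They also leave open what a free hydroxyl would do in place of the group of 8 heavy atoms on the neighbouring ring atom, since that group is the same in all four compounds.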